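The source may report more compounds than this note shows. Statements on the series, on what has been measured and on what is new or still open speak of the compounds shown alone.

In an assay on isolated protein for inhibition of DNA topoisomerase 1 (Homo sapiens), with a stated time of 30 min, tested at 100 uM (on this read-out lower numbers stand for a weaker effect and higher numbers for a stronger effect at the one concentration tested), compound 1 `Oc1ccc(-c2cc(-c3cccc(Cl)c3)nc(-c3ccccn3)c2)cc1` gives 59.4%. Two related compounds carry a different core: compound 3 `Oc1ccc(-c2cc(-c3ccc(Cl)cc3)nc(-c3cccs3)c2)cc1` gives 38.8% and compound 2 `Oc1cccc(-c2cc(-c3ccc(Cl)cc3)nc(-c3cccs3)c2)c1` gives 15.1%. The difference between the core of compound 1 and the core of compound 3 is not broken down here. Within the pair of compound 3 and compound 2 the change is 3-hydroxyphenyl in place of 4-hydroxyphenyl on an aromatic carbon, and it made a step of a number 23.7 percentage points lower from compound 3 to compound 2 (beyond the scatter).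

Compound 4 `Oc1cccc(-c2cc(-c3cccc(Cl)c3)nc(-c3ccccn3)c2)c1` has not been measured. It arises from compound 1 by the same kind of change, (3-hydroxyphenyl in place of 4-hydroxyphenyl on an aromatic carbon), set in a different surrounding, since the place of the change sits meta to a 3-chlorophenyl group and meta to a pyridin-2-yl group rather than meta to a 4-chlorophenyl group and meta to a thiophen-2-yl group. Because the same kind of change gave a number 23.7 percentage points lower from compound 3 to compound 2 (beyond the scatter), a step of about a number 23.4 percentage points lower from compound 1 to compound 4 (beyond the scatter) is expected from compound 1. Compound 4 is therefore estimated at 36%, with a likely span from 15% to 55%.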

Compound 4, a percentage reported as inhibition, at one concentration (the size of the read-out at that concentration, not a potency): 0.4%
Estimate against measurement, compound 4: 35.6 percentage points above; the measured number lies below the stated range.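

Moving the hydroxyl, so that 3-hydroxyphenyl stands in place of 4-hydroxyphenyl, lowers the number on both cores in this assay, and on the core of compound 1 the step is a number 59 percentage points lower from compound 1 to compound 4 (beyond the scatter). The direction of the change carried over from one core to the other, but its size did not: the same change on two cores in this assay, a number 23.7 percentage points lower (beyond the scatter) from compound 3 to compound 2 and a number 59 percentage points lower (beyond the scatter) from compound 1 to compound 4, 35.3 percentage points apart, beyond the scatter of two such steps

The cores differ in two places at once, a 3-chlorophenyl group with a pyridin-2-yl group against a 4-chlorophenyl group with a thiophen-2-yl group, and these compounds do not show which of the two places sets the size of the step.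

Still open, from the compounds shown here alone, is how an amine or a carboxylic acid in place of the hydroxyl would fare on either core.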